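The source may report more compounds than this note shows. Statements on the series, on what has been measured and on what is new or still open speak of the compounds shown alone.

In a functional assay on SiHa cells (Homo sapiens) for inhibition (on this read-out lower numbers stand for stronger inhibition and higher numbers for weaker inhibition), compound 3 `COc1cc(/C=C/C(=O)c2cccc(NC(=O)c3ccccc3)c2)ccc1O` gives 4.57 ug/mL, the lowest of the three numbers recorded. Compound 2 `COc1cc(/C=C/C(=O)c2cccc(N)c2)ccc1O` gives 12.3 ug/mL, and compound 1 `COc1cc(/C=C/C(=O)c2cccc(NC(=O)c3ccc(Cl)c(Cl)c3)c2)ccc1O` gives 25.3 ug/mL. The steps run a 2.7-fold lower number from compound 2 to compound 3 (0.43 log units; beyond the scatter), a 5.5-fold lower number from compound 1 to compound 3 (0.74 log units; beyond the scatter) and a 2.1-fold lower number from compound 1 to compound 2 (0.31 log units; beyond the scatter). Compound 4 `COc1cc(/C=C/C(=O)c2cccc(NC(=O)c3cccs3)c2)ccc1O` differs from compound 3 in one place: thiophen-2-yl in place of phenyl on a carbonyl carbon Only the exchange of the aryl group on that carbonyl carbon bears on this, and it gave a 5.5-fold lower number from compound 1 to compound 3 (0.74 log units; beyond the scatter). For the measured compounds named here, no thiophen-2-yl analogue has been measured, so the step to compound 4 is expected to be small, a 1.1-fold higher number from compound 3 to compound 4 (0.04 log units; within the scatter), with either direction or no move beyond the scatter possible. Compound 4 is therefore estimated at 5 ug/mL, with a range from 2 ug/mL to 13 ug/mL.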

Compound 4, half-maximal inhibitory concentration: 6.57 ug/mL
Estimate against measurement, compound 4: 1.3-fold (0.12 log units) below; the measured number falls inside the stated range.
By their numbers in this assay, from the lowest: compounds 3, 4 and 2 (each within the scatter of the next, the first and the last beyond it); then compound 1.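

In this assay thiophen-2-yl on the carbonyl carbon reads level with phenyl (a 1.4-fold higher number from compound 3 to compound 4 (0.16 log units; within the scatter)), so this place accepts a five-membered aromatic ring with one sulfur atom as well as the six-membered carbon ring. Compound 4 also stays level with the free amine (a 1.9-fold lower number from compound 2 to compound 4 (0.27 log units; within the scatter)) and keeps a clear gap to the 3,4-dichlorophenyl amide (a 3.9-fold lower number from compound 1 to compound 4 (0.59 log units; beyond the scatter)), which alone sits apart. No measured property is available to explain these differences. The compounds shown leave open how furan-2-yl, pyridin-3-yl or cyclohexyl would read on this carbonyl carbon.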